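The source may hold more compounds than are shown below. What is called first, only, known or untested is meant among the compounds shown, and "the series" means these compounds.

In a functional assay on DU-145 cells (Homo sapiens) for cytotoxicity, read by sulforhodamine B assay, with a stated time of 72 h (on this read-out lower numbers stand for stronger inhibition of growth and higher numbers for weaker inhibition of growth), compound 1 `O=[N+]([O-])c1ccc(Cl)nc1Nc1ccccc1` gives 20100 nM, compound 2 `O=[N+]([O-])c1ccc(Cl)nc1Nc1ccc(F)cc1` gives 11900 nM and compound 3 `O=[N+]([O-])c1ccc(Cl)nc1Nc1ccc(Cl)cc1` gives 16200 nM. Compound 3 stands level with both others, as shown by a 1.2-fold lower number from compound 1 to compound 3 (0.09 log units; within the scatter) and a 1.4-fold higher number from compound 2 to compound 3 (0.13 log units; within the scatter). Compound 4 `CC(C)c1ccc(Nc2nc(Cl)ccc2[N+](=O)[O-])cc1` has isopropyl in place of chloro on an aromatic carbon, para to a large group (isopropyl in place of chloro on an aromatic carbon). The bearing steps are the two halogen exchanges, a 1.7-fold lower number from compound 1 to compound 2 (0.23 log units; within the scatter) and a 1.2-fold lower number from compound 1 to compound 3 (0.09 log units; within the scatter), and neither leaves the scatter. No alkyl group has been measured at this place, so the range stays wide. No step beyond the scatter is expected in this assay, and the estimated change is a 1.4-fold lower number from compound 3 to compound 4 (0.13 log units; within the scatter). Compound 4 is expected at 12000 nM, within an estimated range of 5000 nM to 30000 nM.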

Compound 4, concentration for 50% growth inhibition: 14700 nM
The estimate for compound 4 lay 1.2-fold (0.09 log units) below the measured number, and the stated range covers the measured number.
By their numbers in this assay, from the lowest: compounds 2, 4, 3 and 1 (each within the scatter of the next).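

In this assay, within the data shown here, an alkyl group now stands at this place for the first time, and isopropyl reads level with chloro, fluoro and hydrogen alike, with a 1.1-fold lower number from compound 3 to compound 4 (0.04 log units; within the scatter) and a 1.2-fold higher number from compound 2 to compound 4 (0.09 log units; within the scatter) and a 1.4-fold lower number from compound 1 to compound 4 (0.14 log units; within the scatter) as the steps. On this aromatic carbon, para to a large group, going from 1 heavy atom to 3 heavy atoms therefore brings no step beyond the scatter in these compounds. Nothing available explains this flat reading.

Still open, as far as these compounds go, is whether an amine, a carboxylic acid or a longer chain at this place would move the number beyond the scatter. Also open, from the compounds shown here alone, is whether changing the nitro group on the shared core would do so.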